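A few compounds are considered here, and "the series" means these few. Any claim that something is new, unique, unknown or untested is made for them only; others in the source may bear on it.

Working notes on the dienone series in an ADME assay on NHDF cells (Homo sapiens) for cytotoxicity, read by MTT assay, with a stated time of 72 h; on this read-out lower numbers stand for stronger inhibition and higher numbers for weaker inhibition.

Compound 1, `COc1ccc(/C=C2\CCC/C(=C\c3cccc(Br)c3)C2=O)cc1OC`, gives 12400 nM in this assay. Compound 2, `COc1ccc(/C=C2\CCC/C(=C\c3cc(OC)c(OC)c(OC)c3)C2=O)cc1OC`, gives 5800 nM in this assay. Among the two numbers so far, compound 1 stands highest, and its nearest neighbour is compound 2, which lies beyond the scatter below it.

Compound 3, `COc1ccc(/C=C2\CCC/C(=C\c3ccc(O)c(Cl)c3)C2=O)cc1OC`, has not yet been measured in this assay. Compared with compound 1 the change is 3-chloro-4-hydroxyphenyl in place of 3-bromophenyl on a double-bonded chain carbon bound to a double-bonded ring carbon. Among the measured compounds shown here, no measured pair shows this change, so nothing here indicates its size or direction; both measured compounds sit in a narrow band of the read-out, and a step no larger than the gap between compound 1 and compound 2 is the most that the series supports.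

The expected step from compound 1 to compound 3 is estimated at a 1.4-fold lower number from compound 1 to compound 3 (0.14 log units; within the scatter), toward a somewhat lower number, though it may fall within the scatter. For compound 3 the estimate in this assay is 9000 nM, with a range from 3500 nM to 23000 nM.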

Compound 3, half-maximal inhibitory concentration: 21900 nM
Estimate against measurement, compound 3: 2.4-fold (0.39 log units) below, and the stated range covers the measured number.
By their numbers in this assay, from the lowest: compound 2; then compounds 1 and 3 (each within the scatter of the next).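

On this double-bonded chain carbon, 3-chloro-4-hydroxyphenyl in place of 3-bromophenyl gives a 1.8-fold higher number from compound 1 to compound 3 (0.25 log units; within the scatter) in this assay, so this pair of compounds is not separated by the read-out. The entering group carries one hydrogen-bond donor and one hydrogen-bond acceptor where 3-bromophenyl carries none, and adding them together with the exchange of bromine for chlorine leaves the number within the scatter of compound 1. No measurement here bears on the cause of this step.

Among the compounds shown here, the single step changes the halogen and adds the hydroxyl together, so the share of each remains unresolved. As far as these compounds go, it also remains open how a phenyl ring carrying an amine or a carboxylic acid at this place would read in this assay.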